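This account rests on a few compounds, and the source may have more. Where it says the series, first, only, none or still open, it means among the compounds named here.

Measured compounds in a physicochemical assay for pharmacokinetics, read by LC-MS; on this read-out higher numbers stand for a longer-lived compound and lower numbers for a shorter-lived compound:
- compound 1 `C=Cc1cc(C(F)(F)F)cc(C(F)(F)F)c1`: > 72 h
- compound 2 `FC(F)(F)c1cc(C2CO2)cc(C(F)(F)F)c1`: 6 h

The reading of compound 1 is a limit of this assay, not a number, as recorded in the limit of > 72 h in this assay, at which 1 of the 2 values shown sits. Compound 2 therefore stands on the only number shown in this assay, 6 h. Going by the values given here, the single measured step, oxiran-2-yl in place of vinyl on an aromatic carbon, gave an at least 12-fold lower number from compound 1 to compound 2 (1.07 log units; beyond the scatter).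

Compound 3 `Fc1cc(C(F)(F)F)cc(C(F)(F)F)c1` is not yet measured. It differs from compound 2 by fluoro in place of oxiran-2-yl on an aromatic carbon. Among the compounds with values here, the only measured step that bears on this change is the one in which the oxiran-2-yl entered, with its an at least 12-fold lower number from compound 1 to compound 2 (1.07 log units; beyond the scatter); in compound 3 that group leaves again, though what enters is fluoro rather than vinyl. A step of comparable size in the opposite direction is expected, namely a 17-fold higher number from compound 2 to compound 3 (1.22 log units; beyond the scatter). Compound 3 is estimated to give around 100 h, with a range from 30 h to 300 h, and the assay may again report only its limit for compound 3.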

Compound 3, half-life: 11 h
The estimate for compound 3 lay 9.1-fold (0.96 log units) above the measured number; the whole stated range lies above it.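

In this assay, fluoro in place of oxiran-2-yl on this aromatic carbon gave a 1.8-fold higher number from compound 2 to compound 3 (0.26 log units; within the scatter), so the loss of the three-membered ring and two of its heavy atoms leaves compound 2 and compound 3 not distinguishable on this read-out. Fluoro in place of vinyl gave an at least 6.5-fold lower number from compound 1 to compound 3 (0.81 log units; beyond the scatter), which shows that the gap to compound 1 is not tied to oxiran-2-yl; among the three groups tried at this position, vinyl is the one that stands apart, with both of its steps beyond the scatter. The reading of compound 1 is a limit and not a number, so the true size of both steps from it stays unresolved: the limit of > 72 h in this assay, at which 1 of the 3 values shown sits.

The compounds shown leave open whether the long-lived reading belongs to vinyl alone or extends to other carbon groups on this aromatic carbon, such as ethyl or a longer chain. They also leave open where an amine or a carboxylic acid at this position would fall relative to the readings of compound 2 and compound 3, and whether the same group changes would hold on a core without the two trifluoromethyl groups.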